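Acetyl on the oxygen of compound 2

The compounds below may be only part of what the source reports. "The series", "measured", "known", "first", "only" and "open" are said of these compounds alone.

In a functional assay on cells (Homo sapiens) for inhibition (on this read-out lower numbers stand for stronger inhibition and higher numbers for weaker inhibition), compound 1 (`CN(O)/C=C\C(=O)c1ccc([N+](=O)[O-])cc1`) gives > 10000 nM, which is a limit of the assay. Compound 3 (`O=C(/C=C\N(O)Cc1ccccc1)c1ccncc1`) gives 8900 nM. Compound 2 (`O=C(/C=C\N(O)Cc1ccccc1)c1ccc([N+](=O)[O-])cc1`) gives 1700 nM, the lowest number shown. Among the compounds with values here, the only measured step is an at least 5.8-fold lower number from compound 1 to compound 2 (0.76 log units; beyond the scatter), and it starts from the limit of > 10000 nM in this assay, at which 1 of the 3 values shown sits.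

Compound 4 (`CC(=O)ON(/C=C\C(=O)c1ccc([N+](=O)[O-])cc1)Cc1ccccc1`) differs from compound 2 by acetyl in place of hydrogen on an oxygen. The measured step lies at a different place and gives no size for this change. Hence no shift beyond the scatter is expected in this assay, with a slight lean towards a higher number. The expected change is a 1.5-fold higher number from compound 2 to compound 4 (0.17 log units; within the scatter). For compound 4 the estimated value is 2500 nM, with an expected range of 700 nM to 9000 nM.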

Compound 4, half-maximal inhibitory concentration: > 10000 nM
Compound 4 ended at the assay's limit; the forecaster's own chance of this, stated with the estimate: 15%; middle value at least 4.0-fold (0.60 log units) away from the limit.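

Within the data shown here, on the oxygen bound to the amine nitrogen, hydroxy to acetoxy is the first change read at this position, and in this assay it gives an at least 5.8-fold higher number from compound 2 to compound 4 (0.76 log units; beyond the scatter). Compound 4 gives > 10000 nM, which is a limit of the assay. The full size of the step cannot be read, and changes at two different places in compound 2 now lead to this limit: the limit of > 10000 nM in this assay, at which 2 of the 4 values shown sit.

On these data alone, whether methyl or a longer acyl chain such as propionyl on this oxygen would keep the number of compound 2 stays open. Also open, as far as these compounds go, is whether acetyl has a similar effect on compound 3.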